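The compounds below may be only part of what the source reports. "The series", "measured", "known", "first", "only" and "open" are said of these compounds alone.

Working notes on the series.

Three analogues sharing one core have been measured in a functional assay on DU-145 cells (Homo sapiens) for inhibition, read by trypan blue exclusion, with a stated time of 96 h; on this read-out lower numbers stand for stronger inhibition of growth and higher numbers for weaker inhibition of growth. Compound 1 `Cc1ccsc1/C=C(/SCc1ccc(Cl)cc1)C(=O)c1ccc(Br)cc1` gives 25000 nM, the lowest of the three numbers. Compound 2 `Cc1ccsc1/C=C(/SCc1ccc(Cl)cc1)C(=O)c1ccc(Cl)cc1` gives 50000 nM, and compound 3 `Cc1ccc(S/C(=C/c2sccc2C)C(=O)c2ccc(Br)cc2)cc1` gives 50000 nM. The step of a 2.0-fold higher number from compound 1 to compound 2 (0.30 log units; within the scatter) and the step of a 2.0-fold higher number from compound 1 to compound 3 (0.30 log units; within the scatter) both stay within the scatter, so the three compounds cannot be ordered against each other on these data.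

Compound 4 `O=C(/C(=C\c1ccc(Br)cc1)SCc1ccc(Cl)cc1)c1ccc(Br)cc1` is the next candidate for this assay. It differs from compound 1 in one place: 4-bromophenyl in place of 3-methylthiophen-2-yl on a double-bonded chain carbon bound to a double-bonded chain carbon. Neither measured step touches this part of the core; the changes to compound 2 and compound 3 concern the halogen on the aromatic carbon and the group on the sulfur, and both left the read-out within the scatter. There is no information on how an exchange at the double-bonded chain carbon affects the read-out.

Among the compounds with values here, with no relevant step available, the working expectation for compound 4 is a step of a 1.4-fold higher number from compound 1 to compound 4 (0.15 log units; within the scatter), that is, no movement beyond the scatter in either direction, with a wide range to reflect the absence of guidance. Compound 4 is therefore estimated at 35000 nM, expected to fall between 12000 nM and 100000 nM.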

Compound 4, concentration for 50% growth inhibition: 1000 nM
Beside the measured number, compound 4's estimate is 35-fold (1.54 log units) above it; the whole stated range lies above it.
By their numbers in this assay, from the lowest: compound 4; then compounds 1, 2 and 3 (each within the scatter of the next).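

In this assay, the double-bonded chain carbon bound to a double-bonded chain carbon is a place where the read-out moves: 4-bromophenyl in place of 3-methylthiophen-2-yl gives a 25-fold lower number from compound 1 to compound 4 (1.40 log units; beyond the scatter), the only one of the three steps shown that lies beyond the scatter. The change replaces a five-membered aromatic ring with 1 hetero atom by a six-membered aromatic ring of carbon only and also brings in a bromine, and this single step cannot separate the contribution of the ring from that of the bromine. Nothing available here bears on the origin of the step.

On these data alone, it remains open whether the bromine is needed at all, which plain phenyl, 4-chlorophenyl or a pyridine ring at this carbon would test. Also open, as far as these compounds go, is whether the lower number persists when 4-bromophenyl at this carbon is combined with the 4-methylphenyl group on the sulfur of compound 3, or with the chloro in place of bromo on the aromatic carbon of compound 2.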